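Adding 4-chlorophenyl to compound 1

A few compounds are considered here, and "the series" means these few. Any claim that something is new, unique, unknown or untested is made for them only; others in the source may bear on it.

In an ADME assay on HEK-293T cells (Homo sapiens) for inhibition, read by CCK-8 assay, with a stated time of 48 h, tested at 20 uM (on this read-out lower numbers stand for less inhibition of growth and higher numbers for more inhibition of growth at the one concentration tested), compound 1 `Cc1ccc(S(=O)(=O)Oc2ccccc2/C=C(\C#N)C(=O)Nc2nnc(C)s2)cc1` gives 35% of growth inhibition. Compound 2 `COc1ccc(S(=O)(=O)Oc2ccccc2/C=C(\C#N)C(=O)Nc2nnc(Cc3cccc4ccccc34)s2)cc1` gives 29% and compound 3 `N#C/C(=C\c1ccccc1OS(=O)(=O)c1ccc([N+](=O)[O-])cc1)C(=O)Nc1nnc(Cc2cccc3ccccc23)s1` gives 25% in this assay as well, so all three sit within the usual scatter of one another.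

Compound 4 `Cc1ccc(S(=O)(=O)Oc2ccccc2/C=C(\C#N)C(=O)Nc2nnc(Cc3ccc(Cl)cc3)s2)cc1` differs from compound 1 in one place (4-chlorophenyl in place of hydrogen on a saturated chain carbon bound to an aromatic carbon): 4-chlorophenyl stands in place of hydrogen on a saturated chain carbon bound to an aromatic carbon, turning methyl into 4-chlorobenzyl.

Among the measured compounds shown here, the only measured single-place step (a number 4 percentage points lower from compound 2 to compound 3 (within the scatter)) puts nitro in place of methoxy, a different change, and it stays within the scatter. Compound 2 (29%) and compound 3 (25%) also carry an aromatic group on that chain carbon, though they differ from compound 1 elsewhere too, and their values remain within the scatter of compound 1.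

The expected change is a number 5 percentage points lower from compound 1 to compound 4 (within the scatter) and so no step beyond the scatter is expected. For compound 4 the estimated value is 30% with an expected range from 18% to 42% in this measurement.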

Compound 4, percent growth inhibition at one concentration: 20%
Estimate against measurement, compound 4: 10 percentage points above, and the stated range covers the measured number.
By their numbers in this assay, from the lowest: compounds 4, 3, 2 and 1 (each within the scatter of the next, the first and the last beyond it).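

Turning methyl into 4-chlorobenzyl gives a number 15 percentage points lower from compound 1 to compound 4 (beyond the scatter) in this assay, so a single change at this saturated chain carbon moves the read-out beyond the usual scatter. Among the compounds shown here, the only earlier single-place step, a number 4 percentage points lower from compound 2 to compound 3 (within the scatter), was made at a different place and stayed within the scatter, so this is the first sign that the read-out responds to a change in one place. Nothing available explains the reason for this drop.

Still open, on these data alone, is whether the drop belongs to the chlorine or to the ring as a whole, a question that a plain benzyl group in place of 4-chlorobenzyl could help to settle. The compounds shown also leave open how an ethyl group, an amine or a carboxylic acid at this place would read.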